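The compounds below may be only part of what the source reports. "The series", "measured", "known", "first", "only" and "open" are said of these compounds alone.

Measured so far:
compound 1, `CC(C(=O)NCc1ccc(C(C)(C)C)cc1N1CCN(c2ccccc2)CC1)c1ccc(NS(C)(=O)=O)c(F)c1`: 0.8 nM
compound 2, `CC(C)COc1cc(C(C)(C)C)ccc1CNC(=O)C(C)c1ccc(NS(C)(=O)=O)c(F)c1`: 2.1 nM
compound 3, `CC(C(=O)NCc1ccc(C(C)(C)C)cc1OCC(C)(C)C)c1ccc(NS(C)(=O)=O)c(F)c1`: 3.8 nM

In an assay on cells for antagonist activity at transient receptor potential cation channel subfamily V member 1 (Homo sapiens), read by FLIPR and calcium flux, with a stated time of 6 min (on this read-out higher numbers stand for weaker inhibition and lower numbers for stronger inhibition), compound 3 gives the highest number of the three. Its nearest neighbour is compound 2, and the gap between them is within the scatter a 1.8-fold higher number from compound 2 to compound 3 (0.26 log units; within the scatter); compound 1 is furthest away, with a step that is beyond the scatter a 4.8-fold higher number from compound 1 to compound 3 (0.68 log units; beyond the scatter).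

Compound 4, `CC(C(=O)NCc1ccc(C(C)(C)C)cc1SC1CCCCC1)c1ccc(NS(C)(=O)=O)c(F)c1`, differs from compound 3 in a single place: cyclohexylsulfanyl in place of neopentyloxy on an aromatic carbon. The measured steps that touch this aromatic carbon are a 2.6-fold higher number from compound 1 to compound 2 (0.42 log units; beyond the scatter) and a 4.8-fold higher number from compound 1 to compound 3 (0.68 log units; beyond the scatter), both of them modest and both going from a phenylpiperazinyl group to an alkoxy group; the step of a 1.8-fold higher number from compound 2 to compound 3 (0.26 log units; within the scatter) between the two alkoxy groups stays within the scatter. For the measured compounds named here, no measured pair exchanges oxygen for sulfur at this carbon, and none brings in a ring there, so the present change has no direct precedent among the three compounds. On that basis a modest step in either direction is the most that can be expected, with no strong reason to expect a move beyond the scatter. Compound 4 is therefore estimated at 4 nM in this assay, with a range from 1.3 nM to 12 nM. That estimate means an expected step of a 1.1-fold higher number from compound 3 to compound 4 (0.02 log units; within the scatter).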

Compound 4, inhibition constant: 7.4 nM
Compound 4: the middle estimate sits 1.9-fold (0.27 log units) below what was measured, and the stated range covers the measured number.
By their numbers in this assay, from the lowest: compound 1; then compounds 2, 3 and 4 (each within the scatter of the next, the first and the last beyond it).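

In this assay, this aromatic carbon, ortho to a large group, now carries a group joined through sulfur and holding a six-membered non-aromatic ring, and exchanging neopentyloxy for cyclohexylsulfanyl gives a 1.9-fold higher number from compound 3 to compound 4 (0.29 log units; within the scatter), so this pair shows no separation between the two groups. The other two comparisons widen the picture: cyclohexylsulfanyl does separate from isobutoxy, with a 3.5-fold higher number from compound 2 to compound 4 (0.55 log units; beyond the scatter), and the exchange from 4-phenylpiperazin-1-yl gives a 9.3-fold higher number from compound 1 to compound 4 (0.97 log units; beyond the scatter), the largest step yet seen at this carbon, leaving compound 1 with the lowest number of the four. Nothing available accounts for these differences.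

The compounds shown change the linking atom and the ring together, so cyclohexyloxy or an open-chain group such as neopentylsulfanyl would be needed to tell the contribution of sulfur from that of the cyclohexyl ring. They also leave open whether the low number of compound 1 depends on the terminal phenyl or on the ring nitrogen, a question that an unsubstituted piperazin-1-yl or a piperidin-1-yl group at this carbon would address.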